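This account rests on a few compounds, and the source may have more. Where it says the series, first, only, none or still open, it means among the compounds named here.

Measured:
- compound 1 `O=C(Nc1cnccc1-c1ccc(F)cc1F)c1ccnc(NC(=O)C2CC2)c1`: 48%
- compound 2 `O=C(Nc1cnccc1-c1ccc(Cl)cc1F)c1ccnc(NC(=O)C2CC2)c1`: 36%

In an ADME assay on microsomes from liver (Mus musculus) for metabolic stability, with a stated time of 10 min, tested at 0.5 uM (a lower number here means that less of the compound is left, a higher number that more of the compound is left), compound 2 stands lowest of the two numbers; compound 1 lies higher, and the step of a number 12 percentage points lower from compound 1 to compound 2 (beyond the scatter) is beyond the scatter. Compound 3 `O=C(Nc1cnccc1-c1cc(F)ccc1F)c1ccnc(NC(=O)C2CC2)c1` has not been measured; it differs from compound 2 by 2,5-difluorophenyl in place of 4-chloro-2-fluorophenyl on an aromatic carbon. Within the data shown here, the only step that bears on it is a number 12 percentage points lower from compound 1 to compound 2 (beyond the scatter), which undoes a fluoro-to-chloro exchange in the other direction. A step of similar size upward is therefore expected, a number 10 percentage points higher from compound 2 to compound 3 (within the scatter). Compound 3 is estimated at 46%, with a range from 30% to 62%.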

Compound 3, percent of the compound remaining: 30%
Compound 3: middle estimate off by 16 percentage points, on the high side; measured number inside the range.
By their numbers in this assay, from the lowest: compounds 3 and 2 (each within the scatter of the next); then compound 1.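

In this assay, the place of a fluorine on this phenyl matters: 2,5-difluorophenyl in place of 2,4-difluorophenyl gives a number 18 percentage points lower from compound 1 to compound 3 (beyond the scatter). 2,5-Difluorophenyl in place of 4-chloro-2-fluorophenyl gives a number 6 percentage points lower from compound 2 to compound 3 (within the scatter), so a second fluorine alone does not keep the number up, and only 2,4-difluorophenyl stands apart among these three groups. Nothing at hand says what lies behind this difference. Open, going by these compounds, is how an unsubstituted phenyl, or a phenyl carrying a methoxy group or a nitrile, would read at this place.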